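Swapping the Pyridine Attachment Point in Two Amide Chains

A few compounds are considered here, and "the series" means these few. Any claim that something is new, unique, unknown or untested is made for them only; others in the source may bear on it.

Four compounds share a common core, carrying a sulfur-containing chain that ends in an amide bearing a pyridinylmethyl group. Compound 1 `Nc1nc2[nH]c(CCSCCC(=O)NCc3ccccn3)cc2c(=O)[nH]1` has the longer chain and a pyridin-2-yl ring; in a functional assay on A549 cells (Homo sapiens) for antiproliferative activity, read by MTT assay, with a stated time of 72 h, in the presence of a further agent that is not named here (on this read-out lower numbers stand for stronger inhibition and higher numbers for weaker inhibition), compound 1 gives 77300 nM. Compound 2 `Nc1nc2[nH]c(CCSCCC(=O)NCc3ccncc3)cc2c(=O)[nH]1` differs by pyridin-4-yl in place of pyridin-2-yl on a saturated chain carbon bound to an amide-type nitrogen, and in this assay compound 2 gives 7870 nM, so that the change made a 9.8-fold lower number from compound 1 to compound 2 (0.99 log units; beyond the scatter).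

Compound 3 `Nc1nc2[nH]c(CCSCC(=O)NCc3ccccn3)cc2c(=O)[nH]1` carries the pyridin-2-yl ring on a chain shortened by one link; the difference between its core and that of compound 1 is not broken down here. In this assay compound 3 gives 14100 nM, a value within the scatter of compound 2 and beyond the scatter from compound 1.

Compound 4 `Nc1nc2[nH]c(CCSCC(=O)NCc3ccncc3)cc2c(=O)[nH]1` is not yet measured; it differs from compound 3 by pyridin-4-yl in place of pyridin-2-yl on a saturated chain carbon bound to an amide-type nitrogen, the same kind of change seen once already, at the same place. On these data alone, whether the shorter chain preserves the size of that change is unknown, as only the two pairs exist. Compound 4 is expected to show a step of a 6.4-fold lower number from compound 3 to compound 4 (0.81 log units; beyond the scatter), a little smaller than the earlier one because the earlier step rests on a single pair, a 9.8-fold lower number from compound 1 to compound 2 (0.99 log units; beyond the scatter). Compound 4 is therefore estimated at 2200 nM in this assay, with a plausible range from 700 nM to 7000 nM.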

Compound 4, half-maximal inhibitory concentration: 42400 nM
Estimate against measurement, compound 4: 19-fold (1.28 log units) below; the whole stated range lies below it.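

In this assay, pyridin-4-yl in place of pyridin-2-yl on a saturated chain carbon bound to an amide-type nitrogen gave a 3.0-fold higher number from compound 3 to compound 4 (0.48 log units; beyond the scatter), which is opposite in direction to the step seen with the longer chain. The same change therefore does not carry a fixed effect from one core to the other, and the two steps differ by more than repeated measurements would explain: the same change on two cores in this assay, a 9.8-fold lower number (0.99 log units; beyond the scatter) from compound 1 to compound 2 and a 3.0-fold higher number (0.48 log units; beyond the scatter) from compound 3 to compound 4, 30-fold (1.47 log units) apart, beyond the scatter of two such steps

This shows that, within these two pairs, neither the size nor the direction of the step on one core could be relied on for the other, but it does not show why the step reverses, and two pairs cannot establish a general rule linking chain length to the preferred pyridine attachment point.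

The compounds shown leave open whether a longer chain, with a further link beyond that of compound 1, would follow compound 2 in favouring pyridin-4-yl or would instead behave like compound 4. They also leave open how a plain phenyl ring in place of either pyridine would compare on each chain, and so whether the ring nitrogen matters to the reversal at all.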